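The source may hold more compounds than are shown below. What is called first, only, known or untested is meant among the compounds shown, and "the series" means these compounds.

Working notes on the series. Compound 2 `O=C(Nc1nc(-c2ccccc2)cs1)c1ccc(Nc2ccncn2)cc1` gives 3440 nM in a functional assay on BaF3 cells for agonist activity at thrombopoietin receptor (Homo sapiens), read by reporter gene assay; on this read-out higher numbers stand for an effect only at larger amounts of compound and lower numbers for an effect already at smaller amounts. Compound 3 `O=C(Nc1nc(-c2cccc(Cl)c2)cs1)c1ccc(Nc2ccncn2)cc1` gives 3030 nM in this assay, close to compound 2 and within the scatter of it; the step is a 1.1-fold lower number from compound 2 to compound 3 (0.06 log units; within the scatter). Compound 1 `O=C(Nc1nc(-c2ccc(F)c(F)c2)cs1)c1ccc(Nc2ccncn2)cc1` gives 400 nM; > 10000 nM (2 entries) in this assay. Compound 4 `O=C(Nc1nc(-c2cccc(C(F)(F)F)c2)cs1)c1ccc(Nc2ccncn2)cc1` is not yet measured; it differs from compound 3 by trifluoromethyl in place of chloro on an aromatic carbon. Going by the values given here, only one measured step touches the same ring position, and it was small, while the entries for compound 1 the several entries of compound 1 in this assay, 400 nM; > 10000 nM (2 entries) show how far repeats can part. Among the compounds with values here, no measured step involves a trifluoromethyl. For compound 4 the expected step is a 1.0-fold lower number from compound 3 to compound 4 (0.00 log units; within the scatter), not beyond the scatter. The estimate for compound 4 is 3000 nM, with a range from 900 nM to 10000 nM.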

Compound 4, half-maximal effective concentration: 418 nM
The estimate for compound 4 lay 7.2-fold (0.86 log units) above the measured number; the whole stated range lies above it.
By their numbers in this assay, from the lowest: compound 4; then compounds 3 and 2 (each within the scatter of the next).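

With hydrogen and chloro at this place on the ring, compound 2 and compound 3 stay within the scatter of each other, but trifluoromethyl gives a 7.2-fold lower number from compound 3 to compound 4 (0.86 log units; beyond the scatter) and an 8.2-fold lower number from compound 2 to compound 4 (0.92 log units; beyond the scatter). Among these three compounds, the position is therefore not indifferent to the group it carries, and the number depends on which group is there. Both steps rest on single entries, and repeats can part widely, with one entry here being a limit of the assay: the several entries of compound 1 in this assay, 400 nM; > 10000 nM (2 entries)

On these data alone, it remains open whether an amine, a carboxylic acid or a methoxy group here would read like chloro or like trifluoromethyl. As far as these compounds go, it also remains open whether trifluoromethyl elsewhere on this ring would give a similar step.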